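Swapping the Aryl Group on a Shared Core

This account rests on a few compounds, and the source may have more. Where it says the series, first, only, none or still open, it means among the compounds named here.

Compound 1 `Cc1ccc(C)c(-c2nc(CN3CCC(C(=O)NCCCN4C[C@H](C)C[C@H](C)C4)CC3)c(C)o2)c1`: 4070 nM
Compound 2 `Cc1ccccc1-c1nc(CN2CCC(C(=O)NCCCN3CCC(C(C)C)CC3)CC2)c(C)o1`: 4280 nM

Both of these numbers come from an ADME assay on Huh7.5.1 cells (Homo sapiens) for cytotoxicity, read by ATP content, with a stated time of 48 h; on this read-out higher numbers stand for lower toxicity in this test and lower numbers for higher toxicity in this test. Compound 1 has the smaller of the two numbers shown, but the gap to compound 2 lies within the scatter, so on this read-out the two compounds cannot be told apart.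

Compound 3 `Cc1oc(-c2c(F)cccc2F)nc1CN1CCC(C(=O)NCCCN2C[C@H](C)C[C@H](C)C2)CC1` has not yet been measured in this assay. It differs from compound 1 in one place: 2,6-difluorophenyl in place of 2,5-dimethylphenyl on an aromatic carbon. The rest of the shared core of compound 1 is kept unchanged.

Within the data shown here, no step between two measured compounds is available to calibrate a change of this kind, and the two numbers at hand are within the scatter of each other, so they give no direction either. The step from compound 1 to compound 3 is therefore expected to stay within the scatter, a 1.1-fold higher number from compound 1 to compound 3 (0.04 log units; within the scatter), with no direction favoured. Compound 3 is estimated at 4500 nM, with a range from 2000 nM to 10000 nM that allows for the usual variation of this test.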

Compound 3, half-maximal cytotoxic concentration: 32700 nM
Estimate against measurement, compound 3: 7.3-fold (0.86 log units) below, and the stated range ends below it.
By their numbers in this assay, from the lowest: compounds 1 and 2 (each within the scatter of the next); then compound 3.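

The first step read at this position shows that the aryl group on the aromatic carbon of the five-membered aromatic ring matters in this assay: replacing 2,5-dimethylphenyl with 2,6-difluorophenyl gives an 8.0-fold higher number from compound 1 to compound 3 (0.90 log units; beyond the scatter), and the higher number stands for lower toxicity in this test. The two groups match in several counted features, each having 8 heavy atoms, one six-membered aromatic ring of carbon only, no hydrogen-bond donors or acceptors and no net charge, so a change that leaves these counts untouched is still enough to move the read-out beyond the scatter. Nothing measured here explains why this exchange has this effect.

Among these compounds, the single step changes the identity and the placement of the two substituents together, so it cannot say which of them goes with the higher number; a 2,5-difluorophenyl or a 2,6-dimethylphenyl group at this carbon would separate the two. On these data alone, it also remains open whether 2,6-difluorophenyl would have a similar effect on the core of compound 2, which carries a different amine at the end of its side chain.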